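The compounds below may be only part of what the source reports. "The series", "measured", "known", "first", "only" and "open" are said of these compounds alone.

Going by the values given here, compound 2 `NCCS(=O)(=O)CCOc1ccc([C@H]2CC[C@]3(CC2)OOC2(O3)C3CC4CC(C3)CC2C4)cc1` is the only member of this set with a number in an ADME assay on microsomes from liver (Homo sapiens) for metabolic stability, read by LC-MS, tested at 1 uM; a higher number here means faster removal of the compound, a lower number slower removal: in that assay compound 2 gives 9 mL.min-1.g-1. Compound 1 `c1cc([C@H]2CC[C@]3(CC2)OOC2(O3)C3CC4CC(C3)CC2C4)ccc1OCCC1CCNCC1` gives in this assay only a limit, < 7 mL.min-1.g-1. Among the compounds with values here, the single measured step, an at least 1.2-fold higher number from compound 1 to compound 2 (0.10 log units; that floor lies within the scatter), is therefore read against the floor set by that limit (the limit of < 7 mL.min-1.g-1 in this assay, at which 1 of the 2 values shown sits), and its true size is not pinned down. Compound 3 `NCCCCOc1ccc([C@H]2CC[C@]3(CC2)OOC2(O3)C3CC4CC(C3)CC2C4)cc1` is reached from compound 2 by 2-aminoethyl in place of (2-aminoethyl)sulfonyl on a saturated chain carbon, two bonds along the chain from an oxygen on an aromatic ring. Within the data shown here, no measured step covers this exact exchange; the only comparison at hand, an at least 1.2-fold higher number from compound 1 to compound 2 (0.10 log units; that floor lies within the scatter), alters the same place on the chain and, at its floor, lies within the scatter. It is therefore expected that compound 3 will sit close to compound 2, with a step of a 1.3-fold higher number from compound 2 to compound 3 (0.12 log units; within the scatter) and no direction claimed beyond the scatter. The estimate for compound 3 in this assay is 12 mL.min-1.g-1, with a range from 5 mL.min-1.g-1 to 30 mL.min-1.g-1.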

Compound 3, intrinsic clearance in microsomes: < 7 mL.min-1.g-1
Compound 3 gave a limit, no number (the forecaster's own chance of this, stated with the estimate: 25%); middle value at least 1.7-fold (0.23 log units) from the limit.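

Compound 3 gives only a limit in this assay, < 7 mL.min-1.g-1. The exchange of (2-aminoethyl)sulfonyl for 2-aminoethyl at this place on the chain now has a step of its own, an at least 1.2-fold lower number from compound 2 to compound 3 (0.10 log units; that floor lies within the scatter), and its true size is not pinned down. With piperidin-4-yl and 2-aminoethyl both ending at the same limit, compound 2 remains the only compound with a number, and the step from compound 1 to compound 3 cannot be read: the limit of < 7 mL.min-1.g-1 in this assay, at which 2 of the 3 values shown sit.

The compounds shown leave open whether either readable step goes beyond the scatter, and how far under the limit compound 1 and compound 3 truly lie. They also leave open how a carboxylic acid or a longer chain ending in an amine would read at this place in this assay.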